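Bromo in Place of Fluoro: An Expected Potency

The compounds below may be only part of what the source reports. "The series", "measured", "known", "first", "only" and "open" are said of these compounds alone.

Compound 1 `COc1cccc(-n2cc(COc3cccc(NC(=O)Nc4ccc(Cl)c(C(F)(F)F)c4)c3)nn2)c1` gives 1310 nM in a functional assay on HepG2 cells (Homo sapiens) for inhibition, read by MTT assay, with a stated time of 72 h; a lower number here means a stronger inhibitor, a higher number a weaker inhibitor.
Compound 2 `Cc1cccc(-n2cc(COc3cccc(NC(=O)Nc4ccc(Cl)c(C(F)(F)F)c4)c3)nn2)c1` gives 7270 nM in this assay.
Compound 3 `O=C(Nc1cccc(OCc2cn(-c3ccc(F)cc3)nn2)c1)Nc1ccc(Cl)c(C(F)(F)F)c1` gives 1350 nM in this assay.

Compound 3 sits second highest of the three; its number is within the scatter of compound 1, while compound 2 lies beyond it, as a 5.4-fold lower number from compound 2 to compound 3 (0.73 log units; beyond the scatter) shows. Compound 4 `O=C(Nc1cccc(OCc2cn(-c3ccc(Br)cc3)nn2)c1)Nc1ccc(Cl)c(C(F)(F)F)c1` differs from compound 3 only by bromo in place of fluoro on an aromatic carbon. The steps that change the group on the aromatic nitrogen are a 1.0-fold higher number from compound 1 to compound 3 (0.01 log units; within the scatter), within the scatter, and a 5.4-fold lower number from compound 2 to compound 3 (0.73 log units; beyond the scatter), modest; substituent changes on this ring have so far moved the number by at most a modest amount. A bromo for fluoro swap is therefore expected to give a 1.0-fold lower number from compound 3 to compound 4 (0.02 log units; within the scatter), no step beyond the scatter. For compound 4 the estimate is 1300 nM, ranging from 500 nM to 3500 nM.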

Compound 4, half-maximal inhibitory concentration: 2730 nM
The estimate for compound 4 lay 2.1-fold (0.32 log units) below the measured number; the measured number falls inside the stated range.
By their numbers in this assay, from the lowest: compounds 1 and 3 (each within the scatter of the next); then compound 4; then compound 2.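

Going from 4-fluorophenyl to 4-bromophenyl gives a 2.0-fold higher number from compound 3 to compound 4 (0.31 log units; beyond the scatter) in this assay and shows that the halogen alone on this aromatic carbon can move the number, though only modestly. The 4-bromophenyl group also separates from both other aryl groups, with a 2.1-fold higher number from compound 1 to compound 4 (0.32 log units; beyond the scatter) and a 2.7-fold lower number from compound 2 to compound 4 (0.43 log units; beyond the scatter) while 4-fluorophenyl stayed within the scatter of 3-methoxyphenyl. Nothing available explains these steps.

The compounds shown leave open how a chloro, a nitrile or an amine on this same aromatic carbon would read in this assay and whether the halogen step would hold on another aryl group.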